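This account rests on a few compounds, and the source may have more. Where it says the series, first, only, none or still open, it means among the compounds named here.

Compound 1 `O=C1NC(=S)/C(=C/c2ccc(Cl)cc2)S1`: 28.6%
Compound 2 `O=C1NC(=S)/C(=C/c2ccc(Br)cc2)S1`: 1.19%

For the measured compounds named here, in a functional assay on NCI-H292 cells (Homo sapiens) for cytotoxicity, read by MTT assay, with a stated time of 72 h, tested at 2.5 ug/mL (on this read-out higher numbers stand for more inhibition of growth at the one concentration tested and lower numbers for less inhibition of growth), compound 2 gives 1.19%, the lower of the two numbers measured so far, and compound 1 is its only neighbour. The next compound, compound 3 `O=C1NC(=S)/C(=C/c2ccc(F)cc2)S1`, brings one structural change: fluoro in place of bromo on an aromatic carbon. In words, this is fluoro in place of bromo on an aromatic carbon. Going by the values given here, only one measured step bears on this change: a number 27.4 percentage points lower from compound 1 to compound 2 (beyond the scatter), a modest step beyond the scatter, with bromo in place of chloro on an aromatic carbon. Among the compounds with values here, no fluoro compound has yet been measured, so this single step gives only a rough guide. With compound 2 at 1.19%, an upward step of modest size, perhaps smaller than that one, is expected. The estimated step is a number 14.8 percentage points higher from compound 2 to compound 3 (beyond the scatter). For compound 3 the estimate is 16%, with an expected range of 0% to 40%.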

Compound 3, percent growth inhibition at one concentration: 17.5%
For compound 3 the middle estimate is 1.5 percentage points below the measured one; measured number inside the range.
By their numbers in this assay, from the lowest: compound 2; then compound 3; then compound 1.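

In this assay, fluoro in place of bromo on this aromatic carbon gives a number 16.3 percentage points higher from compound 2 to compound 3 (beyond the scatter), while fluoro in place of chloro gives a number 11.1 percentage points lower from compound 1 to compound 3 (beyond the scatter). Fluoro therefore places compound 3 between the other two halogen compounds, so the numbers do not rise or fall steadily in the sequence fluoro, chloro, bromo, and the very low number of compound 2 goes with bromo alone among these three. Nothing available explains this order of the three halogens.

From the compounds shown here alone, what remains open is whether a non-halogen group on the same carbon, such as a methoxy group, an amine or a carboxylic acid, would give a number inside or outside the range of these three compounds. Going by these compounds, it is also open whether their order would hold at other concentrations.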